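Chain extension on the nitrile analogue: compound 3 to compound 4

This account rests on a few compounds, and the source may have more. Where it says the series, first, only, none or still open, it means among the compounds named here.

Measured in a functional assay on HeLa cells (Homo sapiens) for inhibition, read by MTT assay, with a stated time of 72 h (a lower number here means a stronger inhibitor, a higher number a weaker inhibitor), so far:
- compound 1 `C/C=C/C(=O)Nc1cccc(Oc2nc(Nc3cccc(OC)c3)nc3ccsc23)c1`: 20100 nM
- compound 2 `CC/C=C/C(=O)Nc1cccc(Oc2nc(Nc3cccc(OC)c3)nc3ccsc23)c1`: 29400 nM
- compound 3 `C/C=C/C(=O)Nc1cccc(Oc2nc(Nc3cccc(C#N)c3)nc3ccsc23)c1`: 23600 nM

Compound 3 stands second highest of the three numbers. Its nearest neighbour is compound 1, with a step of a 1.2-fold higher number from compound 1 to compound 3 (0.07 log units; within the scatter) between them; compound 2 gives a number within the scatter of compound 3 as well, so no order among the three can be read.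

Compound 4 `CC/C=C/C(=O)Nc1cccc(Oc2nc(Nc3cccc(C#N)c3)nc3ccsc23)c1` is not yet measured. It differs from compound 3 by methyl in place of hydrogen on a saturated chain carbon bound to a double-bonded chain carbon. The same change has been seen once, on the methoxy analogue, as a 1.5-fold higher number from compound 1 to compound 2 (0.17 log units; within the scatter), a step within the scatter. Since the methoxy-to-cyano swap itself gave only a 1.2-fold higher number from compound 1 to compound 3 (0.07 log units; within the scatter), the step on the nitrile analogue is expected to look alike: at most a slight move toward a higher number, not beyond the scatter, in this assay.

For compound 4 the expected step is therefore a 1.3-fold higher number from compound 3 to compound 4 (0.12 log units; within the scatter). Compound 4 is estimated at 31000 nM, with a range of 15000 nM to 65000 nM.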

Compound 4, half-maximal inhibitory concentration: 69400 nM
Compound 4: the middle estimate sits 2.2-fold (0.35 log units) below what was measured; measured number above the stated range.
By their numbers in this assay, from the lowest: compounds 1, 3 and 2 (each within the scatter of the next); then compound 4.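

In this assay, methyl in place of hydrogen on the saturated chain carbon bound to a double-bonded chain carbon now gives a step beyond the scatter, a 2.9-fold higher number from compound 3 to compound 4 (0.47 log units; beyond the scatter), and cyano in place of methoxy on an aromatic carbon also does so with the but-1-en-1-yl chain present, a 2.4-fold higher number from compound 2 to compound 4 (0.37 log units; beyond the scatter). This position is therefore not silent to one added methyl in every compound shown, but the larger step on the nitrile analogue cannot be separated from the smaller one on the methoxy analogue: the same change on two cores in this assay, a 1.5-fold higher number (0.17 log units; within the scatter) from compound 1 to compound 2 and a 2.9-fold higher number (0.47 log units; beyond the scatter) from compound 3 to compound 4, 2.0-fold (0.30 log units) apart, within the scatter of two such steps. Nor does the cyano change establish a dependence on the chain: the same change on two cores in this assay, a 1.2-fold higher number (0.07 log units; within the scatter) from compound 1 to compound 3 and a 2.4-fold higher number (0.37 log units; beyond the scatter) from compound 2 to compound 4, 2.0-fold (0.30 log units) apart, within the scatter of two such steps.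

The compounds shown leave open whether a longer chain than but-1-en-1-yl would continue this trend. As far as these compounds go, the effect of an amine on the chain also remains open.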